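The compounds below may be only part of what the source reports. "The series", "measured", "known", "first", "only" and "open" are said of these compounds alone.

Compound 3 `CC(C)Nc1nc(Nc2ccc(N3CCN(C)CC3)cc2)ncc1/N=C/c1cccs1` carries a thiophen-2-yl group on a carbon with a double bond to nitrogen. In a functional assay on MCF7 cells (Homo sapiens) for antiproliferative activity, read by MTT assay (on this read-out higher numbers stand for weaker inhibition and lower numbers for stronger inhibition), compound 3 gives 91100 nM, the highest of the two numbers recorded here. The nearest number belongs to compound 1 `CCOC(=O)/C=N/c1cnc(Nc2ccc(N3CCN(C)CC3)cc2)nc1NC(C)C`, which in this assay gives 12300 nM. Compound 2 `CC(C)Nc1nc(Nc2ccc(N3CCN(C)CC3)cc2)ncc1/N=C/c1ccccc1` gives > 100000 nM in this assay, and that value is a limit of the assay rather than a number, the one case of this kind among the three values (the limit of > 100000 nM in this assay, at which 1 of the 3 values shown sits).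

Among the measured steps, replacing ethoxycarbonyl by thiophen-2-yl produced a 7.4-fold higher number from compound 1 to compound 3 (0.87 log units; beyond the scatter), and replacing it by phenyl produced an at least 8.1-fold higher number from compound 1 to compound 2 (0.91 log units; beyond the scatter). The swap most like the one in question, thiophen-2-yl for phenyl, showed an at least 1.0-fold lower number from compound 2 to compound 3 (0.04 log units; that floor lies within the scatter).

Compound 4 `CC(C)Nc1nc(Nc2ccc(N3CCN(C)CC3)cc2)ncc1/N=C/c1ccc(C(F)(F)F)cc1` differs from compound 3 in one place: 4-(trifluoromethyl)phenyl in place of thiophen-2-yl on a carbon with a double bond to nitrogen. The entering group is a six-membered aromatic ring of carbon only, as in compound 2, so the relevant comparison is the step from compound 2 to compound 3, which stayed within the scatter. The expected step in this assay is therefore small, a 1.3-fold higher number from compound 3 to compound 4 (0.12 log units; within the scatter), with the number more likely to rise than to fall. Compound 4 is estimated at 120000 nM, in a range from 50000 nM to 300000 nM, with a fair chance that only a limit is reported.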

Compound 4, half-maximal inhibitory concentration: > 100000 nM
Compound 4: only a limit was reported; the forecaster's own chance of this, stated with the estimate: 55%; the middle value lies beyond the limit too.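

Replacing ethoxycarbonyl by 4-(trifluoromethyl)phenyl gives an at least 8.1-fold higher number from compound 1 to compound 4 (0.91 log units; beyond the scatter) in this assay, so all three aromatic groups shown on this carbon with a double bond to nitrogen now stand on the weaker side of compound 1, with no listed compound going against that. The swap of thiophen-2-yl for 4-(trifluoromethyl)phenyl gives an at least 1.0-fold higher number from compound 3 to compound 4 (0.04 log units; that floor lies within the scatter), so even a ring carrying trifluoromethyl cannot be told apart from the thiophen-2-yl ring on these figures. The step from compound 2 to compound 4 cannot be read, which means the effect of adding trifluoromethyl to the phenyl ring stays hidden, and the upper end of the assay now limits what this series can show: the limit of > 100000 nM in this assay, at which 2 of the 4 values shown sit.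

As far as these compounds go, it remains open whether any group on this carbon can give a lower number than compound 1 does at 12300 nM, for example a carboxylic acid, an amide or a short alkyl chain in place of ethoxycarbonyl. From the compounds shown here alone, it is also open whether an aromatic ring carrying an amine or a hydroxyl group would bring the number back down from the limit.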